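A Second Hydroxy Group on the Shared Core

The source may report more compounds than this note shows. Statements on the series, on what has been measured and on what is new or still open speak of the compounds shown alone.

Of the compounds shown here, two have been measured so far. Compound 1 `N#Cc1c(Nc2ccc(Cl)cc2)nc(SCC(=O)Nn2c(COc3ccc(Cl)cc3Cl)nc3ccccc3c2=O)nc1-c1ccccc1` gives 57.9% in a functional assay on the whole organism (strain albino) for inhibition, with Rattus norvegicus as the target, read by paw edema, with stated times of 1 h and 2 h, at a dose of 100 mg/kg by the oral route; on this read-out higher numbers stand for more inhibition at the one dose given (going by the name of the read-out) and lower numbers for less inhibition. Compound 2 `N#Cc1c(Nc2ccc(O)cc2)nc(SCC(=O)Nn2c(COc3ccc(Cl)cc3Cl)nc3ccccc3c2=O)nc1-c1ccccc1` gives 59.7% in this assay. Among the compounds with values here, the single measured step, a number 1.8 percentage points higher from compound 1 to compound 2 (within the scatter), is the only comparison available. On these two numbers compound 2 stands highest, but its nearest neighbour, compound 1, lies within the usual scatter of it, so no order between the two can be claimed.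

Compound 3 `N#Cc1c(Nc2ccc(O)cc2)nc(SCC(=O)Nn2c(COc3ccc(Cl)cc3Cl)nc3ccccc3c2=O)nc1-c1ccc(O)cc1` is the next member, differing from compound 2 by hydroxy in place of hydrogen on an aromatic carbon; cut one bond further out, the change reads phenyl to 4-hydroxyphenyl. Within the data shown here, no measured step alters this ring. Among the measured compounds shown here, the one step that exists, which brought a hydroxy group in elsewhere, was within the scatter, so an estimated step of a number 0.7 percentage points lower from compound 2 to compound 3 (within the scatter) is taken, that is, none beyond the scatter. The estimate for compound 3 in this assay is therefore 59%, with a range from 46% to 72%.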

Compound 3, a percentage reported as inhibition, in the whole organism at one dose (the size of the read-out at that dose, not a potency): 86.8%
Compound 3: middle estimate off by 27.8 percentage points, on the low side; the whole stated range lies below it.
By their numbers in this assay, from the lowest: compounds 1 and 2 (each within the scatter of the next); then compound 3.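

Phenyl to 4-hydroxyphenyl is the first change in this series to shift the read-out in this assay beyond the scatter, with a number 27.1 percentage points higher from compound 2 to compound 3 (beyond the scatter) set against a number 1.8 percentage points higher from compound 1 to compound 2 (within the scatter) for the earlier change on another ring. Within the data shown here, the aromatic ring that no earlier step had touched therefore proves sensitive to substitution: a single hydroxy group entering para to a large group, in place of a hydrogen atom, separates two compounds that otherwise share every atom, whereas hydroxy in place of chloro on the other ring gave no order between compound 1 and compound 2. No evidence at hand bears on what lies behind this difference.

The compounds shown do not tell whether hydroxy is specifically required at this place or whether a methoxy group, an amine or a carboxylic acid there would give a similar number in this assay. They also leave open whether the 4-hydroxyphenyl group would have the same effect on its own, with chloro rather than hydroxy on the other ring, as compound 3 carries both hydroxy groups.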